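Swapping the fluorophenyl amide for a cyanophenyl

The source may hold more compounds than are shown below. What is called first, only, known or untested is meant among the compounds shown, and "the series" means these compounds.

Compound 2 `CN(C)C(=O)c1cc2cnc(Nc3ccc(NC(=O)C4(C(=O)Nc5cccc(F)c5)CC4)cc3)nc2n1C1CCCC1` stands lowest of the three compounds measured in a functional assay on A549 cells (Homo sapiens) for inhibition, read by CCK-8 assay, with a stated time of 72 h, tested at 1 uM (on this read-out higher numbers stand for more inhibition of growth at the one concentration tested and lower numbers for less inhibition of growth), where compound 2 gives 33.2%. Compound 1 `COC(=O)c1ccc(NC(=O)C2(C(=O)Nc3ccc(Nc4ncc5cc(C(=O)N(C)C)n(C6CCCC6)c5n4)cc3)CC2)cc1` gives 77.1%, and compound 3 `CN(C)C(=O)c1cc2cnc(Nc3ccc(NC(=O)C4(C(=O)Nc5ccc(O)cc5)CC4)cc3)nc2n1C1CCCC1` gives 93.6%. Compound 4 `CN(C)C(=O)c1cc2cnc(Nc3ccc(NC(=O)C4(C(=O)Nc5ccc(C#N)cc5)CC4)cc3)nc2n1C1CCCC1` differs from compound 2 in one place: 4-cyanophenyl in place of 3-fluorophenyl on an amide-type nitrogen. For the measured compounds named here, two measured steps bear on this change, the step of a number 43.9 percentage points lower from compound 1 to compound 2 (beyond the scatter) and the step of a number 60.4 percentage points higher from compound 2 to compound 3 (beyond the scatter), and both show the 3-fluorophenyl group going with a markedly weaker number than either of the other two aryl groups. The 4-cyanophenyl group is expected to behave more like those, so a large rise is estimated, a number 34.8 percentage points higher from compound 2 to compound 4 (beyond the scatter). Compound 4 is therefore expected to give about 68% in this assay, within a range from 45% to 88%.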

Compound 4, percent growth inhibition at one concentration: 86.1%
Compound 4: middle estimate off by 18.1 percentage points, on the low side; the range from low to high includes it.
By their numbers in this assay, from the lowest: compound 2; then compounds 1, 4 and 3 (each within the scatter of the next, the first and the last beyond it).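

In this assay the step of a number 52.9 percentage points higher from compound 2 to compound 4 (beyond the scatter) sets a third aryl group on this amide-type nitrogen well clear of 3-fluorophenyl, so the low number of compound 2 now stands alone among the groups shown. The steps of a number 7.5 percentage points lower from compound 3 to compound 4 (within the scatter) and a number 9 percentage points higher from compound 1 to compound 4 (within the scatter) both lie within the scatter, so cyano cannot be told apart from hydroxy or methoxycarbonyl on this aromatic carbon. Still open, as far as these compounds go, is whether the low number goes with the fluorine itself or with where it sits, which 4-fluorophenyl would separate, and how an amine or a carboxylic acid would read in this place. Nothing measured here accounts for the gap.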